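Removing a Chlorine: Expected Effect on Cell Growth

The source may hold more compounds than are shown below. What is called first, only, known or untested is meant among the compounds shown, and "the series" means these compounds.

Three compounds have been measured in a functional assay on U-87MG ATCC cells for antiproliferative activity against U-87 MG (Homo sapiens), read by MTT assay, with a stated time of 48 h, tested at 5 uM; a lower number here means a stronger effect, a higher number a weaker effect of the compound at the concentration tested:

Compound 1, `COc1ccc(-c2nc(SCC(=O)c3sc(-c4ccccc4)nc3C)[nH]c(=O)c2C#N)cc1`, gives 97.3%.
Compound 2, `Cc1nc(-c2ccccc2)sc1C(=O)CSc1nc(-c2cccc(Cl)c2)c(C#N)c(=O)[nH]1`, gives 86.9%.
Compound 3, `COc1ccc(-c2nc(SCC(=O)c3sc(-c4ccc(Cl)cc4)nc3C)[nH]c(=O)c2C#N)cc1`, gives 92.1%.

Compound 3 and compound 1 share a core and differ at one point: hydrogen in place of chloro on an aromatic carbon. In this assay the result is a number 5.2 percentage points higher from compound 3 to compound 1 (within the scatter). Compound 1 and compound 2 differ at another point, and there the result is a number 10.4 percentage points lower from compound 1 to compound 2 (beyond the scatter). Compound 2 has the lowest number of the three, but the gap to compound 3 falls within the scatter, so no ranking between those two can be claimed. The difference between the cores of compound 2 and compound 3 is not broken down here.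

Compound 4, `Cc1nc(-c2ccccc2)sc1C(=O)CSc1nc(-c2ccccc2)c(C#N)c(=O)[nH]1`, has not yet been measured. It differs from compound 2 by hydrogen in place of chloro on an aromatic carbon. Among the measured compounds shown here, this is the same kind of change as the one from compound 3 to compound 1, though not the same: in one case the place is para to a large group, in the other meta to a large group.

Given that from compound 3 to compound 1 the change gave only a number 5.2 percentage points higher from compound 3 to compound 1 (within the scatter), the step from compound 2 to compound 4 is expected to be similarly small, about a number 4.1 percentage points higher from compound 2 to compound 4 (within the scatter). Compound 4 is therefore estimated to give 91%, most likely between 82% and 99%.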

Compound 4, a percentage reported as activity, at one concentration (the size of the read-out at that concentration, not a potency): 92.1%
Estimate against measurement, compound 4: 1.1 percentage points below, within the range that was stated.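

In this assay, the swap of chloro for hydrogen can now be read on two cores, and the two steps agree: the same change on two cores in this assay, a number 5.2 percentage points higher (within the scatter) from compound 3 to compound 1 and a number 5.2 percentage points higher (within the scatter) from compound 2 to compound 4, 0 percentage points apart, within the scatter of two such steps

The new step, a number 5.2 percentage points higher from compound 2 to compound 4 (within the scatter), therefore shows that removing this chloro group, here leaving 3-chlorophenyl as phenyl, has no effect that can be told apart from the ordinary spread of repeated measurements, and the other swap at this ring, a number 5.2 percentage points lower from compound 1 to compound 4 (within the scatter), is no larger than that spread either. Among the compounds shown here, the agreement does not show that the chloro swap has a real effect that transfers from core to core: both steps are too small to separate from no change, the chloro group sits at a different place in each pair, and only two cores at a single concentration are involved, so the result says nothing about potency or about other cores.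

The compounds shown leave open what a quite different group on this phenyl ring, such as an amine or a carboxylic acid, would do to the read-out. They also leave open what would happen if the nitrile on the shared core gave way to a carboxylic acid or the methyl group to a longer chain.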